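One Added Methyl on a Growth-Inhibiting Compound

The source may report more compounds than this note shows. Statements on the series, on what has been measured and on what is new or still open speak of the compounds shown alone.

In a functional assay on K562 cells (Homo sapiens) for inhibition, read by trypan blue exclusion, with a stated time of 24 h, tested at 10 uM (a lower number here means less inhibition of growth, a higher number more inhibition of growth at the concentration tested), compound 1 (`Cc1ccc(OCC(=O)Nc2ccc(I)cc2C(N)=O)cc1`) gives 49.8% and compound 2 (`Cc1ccc(NC(=O)COc2ccccc2)c(C(N)=O)c1`) gives 72% as the higher of the two numbers. Compound 2 therefore stands at the top of this small set, and its gap to compound 1 lies beyond the usual scatter.

The next compound is compound 3 (`Cc1ccc(OCC(=O)Nc2ccc(C)cc2C(N)=O)cc1`). It is compound 2 with methyl in place of hydrogen on an aromatic carbon, which turns phenyl into 4-methylphenyl. Within the data shown here, no measured pair shows this change on its own, so the size of the step is uncertain. Compound 1 also carries a 4-methylphenyl group and sits lower (49.8%), but it differs elsewhere too, so it offers only a weak hint of a fall. The expected change (a number 9 percentage points lower from compound 2 to compound 3 (within the scatter)) is a small drop in this assay that stays within the scatter. For compound 3 the estimated value is 63% with an expected range from 45% to 80% across repeated measurements.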

Compound 3, percent growth inhibition at one concentration: 30.3%
Compound 3: middle estimate off by 32.7 percentage points, on the high side; measured number below the stated range.
By their numbers in this assay, from the lowest: compound 3; then compound 1; then compound 2.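

Among these compounds, the single added methyl, on an aromatic carbon para to a large group, gives a number 41.7 percentage points lower from compound 2 to compound 3 (beyond the scatter) in this assay, the first measured pair to show this change on its own and a sign that growth inhibition at this concentration depends strongly on what sits at this position. A second single change, methyl in place of iodo on an aromatic carbon elsewhere in the molecule, also goes downward, with a number 19.5 percentage points lower from compound 1 to compound 3 (beyond the scatter), so compound 3 stands lowest of these compounds, beyond the scatter from each of the others. Nothing measured here tells why either change lowers the number.

From the compounds shown here alone, with only hydrogen and methyl seen at the first position, it remains open whether the fall is particular to methyl or would also follow from a chlorine atom, a methoxy group or a longer chain such as ethyl. Going by these compounds, it is also open whether the hydrogen-to-methyl step keeps its size on a core that carries iodo, or on one that carries an amine at that same place.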